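Swapping One Aromatic Group on Compound 3

This account rests on a few compounds, and the source may have more. Where it says the series, first, only, none or still open, it means among the compounds named here.

In a functional assay on B16 cells (Mus musculus) for cytotoxicity, read by MTT assay, with a stated time of 48 h (on this read-out higher numbers stand for weaker inhibition and lower numbers for stronger inhibition), compound 1 (`C=C1CCC[C@]2(C)CCC(C=O)=CC[C@@]12C`) gives 230000 nM and compound 2 (`C#CC1=CC[C@]2(CC1)C(=C)CC[C@H]2C(C)C`) gives 123000 nM while compound 3 (`C=C1CCC[C@]2(C)CCC(c3cn(-c4ccc(OC)cc4)nn3)=CC[C@@]12C`) gives 209000 nM as its number. Compound 3 stands within the usual scatter of both others, so no order can be read among the three. Compound 4 (`C=C1CCC[C@]2(C)CCC(c3cn(-c4ccccc4C(C)=O)nn3)=CC[C@@]12C`) has 2-acetylphenyl in place of 4-methoxyphenyl on an aromatic nitrogen. Within the data shown here, no two measured compounds differ in just one place, so this swap has no direct precedent here. With compound 3 at 209000 nM and so close to the others, little movement is expected. The estimated 1.2-fold lower number from compound 3 to compound 4 (0.09 log units; within the scatter) is small and stays within the scatter. For compound 4 the estimate is 170000 nM with an expected range from 70000 nM to 320000 nM in this measurement.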

Compound 4, half-maximal inhibitory concentration: 42200 nM
Compound 4: middle estimate off by 4.0-fold (0.61 log units), on the high side; the whole stated range lies above it.
By their numbers in this assay, from the lowest: compound 4; then compounds 2, 3 and 1 (each within the scatter of the next).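

Putting 2-acetylphenyl in place of 4-methoxyphenyl on the aromatic nitrogen gives a 5.0-fold lower number from compound 3 to compound 4 (0.69 log units; beyond the scatter) in this assay and so means stronger inhibition. Among these compounds, this shows that the group on this nitrogen can move the number beyond the scatter, which the earlier compounds could not show. No measurement here explains why this swap has that effect. The compounds shown leave open whether the acetyl group alone accounts for the step or whether its place on the phenyl ring matters too. Going by these compounds, it also remains open how an amine or a carboxylic acid on that ring would behave.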